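Three Nitrones at the Assay Limit and a tert-Butyl Analogue

The source may report more compounds than this note shows. Statements on the series, on what has been measured and on what is new or still open speak of the compounds shown alone.

Compound 1 `[O-]/[N+](=C\c1cn(-c2ccccc2)nn1)c1ccccc1`: in a functional assay on A549 cells (Homo sapiens) for inhibition, read by MTT assay, with a stated time of 24 h (a lower number here means a stronger inhibitor, a higher number a weaker inhibitor), compound 1 gives > 100000 nM, a limit of the assay.
Compound 2 `[O-]/[N+](=C\c1cn(-c2ccccc2)nn1)Cc1ccccc1`: in this assay compound 2 gives > 100000 nM, a limit of the assay.
Compound 3 `[O-]/[N+](=C\c1cn(-c2ccc(C(F)(F)F)cc2)nn1)Cc1ccccc1`: in this assay compound 3 gives > 100000 nM, a limit of the assay.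

Compound 2 thus stands at the limit rather than at a number, as do both of its measured neighbours, because all three sit at the limit of > 100000 nM in this assay, at which 3 of the 3 values shown sit. The step that the two limits leave unreadable from compound 1 to compound 2 cannot be sized, and the step that the two limits leave unreadable from compound 2 to compound 3 cannot be sized either.

Compound 4 `CC(C)(C)/[N+]([O-])=C/c1cn(-c2ccccc2)nn1` differs from compound 2 by tert-butyl in place of benzyl on a double-bonded nitrogen. Both measured steps touch the same core, one on the same double-bonded nitrogen, yet neither yields a readable size, so they bear on the new step only by showing that this core has not left the limit so far. No step beyond the scatter is expected; the step of a number no higher from compound 2 to compound 4 (the limit leaves the size open) is an estimate resting on compound 2 sitting at its limit. Compound 4 is expected in this assay to give about 100000 nM, between 30000 nM and 300000 nM, most likely again reported only as a limit.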

Compound 4, half-maximal inhibitory concentration: 17400 nM
The estimate for compound 4 lay 5.7-fold (0.76 log units) above the measured number; measured number below the stated range.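

In this assay, the group on the double-bonded nitrogen proves able to move the read-out: tert-butyl gives an at least 5.7-fold lower number from compound 2 to compound 4 (0.75 log units; beyond the scatter), and the change from phenyl gives an at least 5.7-fold lower number from compound 1 to compound 4 (0.75 log units; beyond the scatter). Among the compounds shown, only compound 4 gives a number, 17400 nM, so this position is the first place on the shared core where a change has a readable effect. The earlier steps shown here cannot be read, and the two new steps have only a minimum size, since their starting compounds remain at a limit: the limit of > 100000 nM in this assay, at which 3 of the 4 values shown sit.

The compounds shown do not tell whether the gain is specific to tert-butyl or would also appear with an isopropyl or a cyclohexyl group on this nitrogen. Nor do they show whether trifluoromethyl on the aromatic ring would change the number of compound 4.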